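Shortening an ethyl to a methyl on a shared core

The source may report more compounds than this note shows. Statements on the series, on what has been measured and on what is new or still open speak of the compounds shown alone.

Compound 1 `CCc1ccc(NC2=NCCC3(CCCCC3)S2)cc1` carries an ethyl group on its aromatic ring. In a physicochemical assay for lipophilicity, at pH 7.4 (a higher number here means a more lipophilic compound, a lower number a more polar compound), compound 1 gives 1.75. Within the data shown here, only one other compound has been measured alongside it: compound 2 `Clc1ccc(NC2=NCCC3(CCCCC3)S2)cc1Cl`, which in this assay gives 1.24. Of these two numbers, the value of compound 1 is the higher. The gap between the two values is larger than the usual scatter of repeated measurements. Among the measured compounds shown here, compound 1 stands clearly above its only neighbour.

Compound 3 `Cc1ccc(NC2=NCCC3(CCCCC3)S2)cc1` shares the same core and differs from compound 1 in a single place: hydrogen in place of methyl on a saturated chain carbon bound to an aromatic carbon Seen one bond further out, this is an ethyl becoming a methyl, so compound 3 has one carbon less than compound 1.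

For the measured compounds named here, no step between two measured compounds shows the effect of removing a single saturated carbon on this core, so the expectation rests on the size of the change alone. With one carbon fewer, compound 3 is expected to give a somewhat lower number in this assay than compound 1, a drop of roughly a number 0.40 log units lower from compound 1 to compound 3 (beyond the scatter), near the edge of the scatter. For compound 3 the estimated value in this assay is 1.35, expected to fall between 0.95 and 1.75.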

Compound 3, distribution coefficient: 1.48
Estimate against measurement, compound 3: 0.13 log units below; the range from low to high includes it.
By their numbers in this assay, from the lowest: compounds 2, 3 and 1 (each within the scatter of the next, the first and the last beyond it).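

Among these compounds, this is the first step on the shared core in which only one place changes, so it gives a direct reading of ethyl to methyl on a saturated chain carbon bound to an aromatic carbon. In this assay the step reads a number 0.27 log units lower from compound 1 to compound 3 (within the scatter) and so lies no further apart than repeated measurements of a single compound can, which means that this assay does not separate the ethyl compound from the methyl compound. Nothing measured speaks to why the step has this size.

The compounds shown leave open whether a longer chain such as propyl or butyl at this same place would give a step that stands clear of the scatter, or whether removing the methyl group of compound 3 as well, to leave a hydrogen on the aromatic carbon, would do so. They also leave open how a different kind of group, such as an amine or a carboxylic acid on this chain, would read in this assay on the same core.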